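The compounds below may be only part of what the source reports. "The series", "measured", "known", "first", "only" and "open" are said of these compounds alone.

Measured in a functional assay on SEM cells (Homo sapiens) for cytotoxicity, with a stated time of 72 h (on this read-out higher numbers stand for an effect only at larger amounts of compound and lower numbers for an effect already at smaller amounts), each value a limit and not a number:
compound 1 `C=C[C@@](C)(/C=C/c1ccc(Nc2ccc(F)cc2)cc1)CCC=C(C)C` gives > 36600 nM
compound 2 `C=C[C@@](C)(/C=C/c1ccc(Nc2cc(F)c(F)cc2F)cc1)CCC=C(C)C` gives > 36600 nM
compound 3 `C=C[C@@](C)(/C=C/c1ccc(Nc2cc(F)c(F)c(F)c2)cc1)CCC=C(C)C` gives > 36600 nM

Compound 3 stands at a limit of the assay, > 36600 nM, and has no number of its own. The series as a whole shows (the limit of > 36600 nM in this assay, at which 3 of the 3 values shown sit), so its three compounds cannot be ranked.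

Compound 4 `C=C[C@@](C)(/C=C/c1ccc(Nc2c(F)cc(F)cc2F)cc1)CCC=C(C)C` is the next case. The change is 2,4,6-trifluorophenyl in place of 3,4,5-trifluorophenyl on a nitrogen on an aromatic ring.

Three measured steps rearrange or add fluorines on this same ring: a step that the two limits leave unreadable from compound 1 to compound 2, a step that the two limits leave unreadable from compound 1 to compound 3 and a step that the two limits leave unreadable from compound 2 to compound 3. The last is the closest parallel, but none of the three has a size that can be carried over. Among the compounds with values here, no direction or readable step is therefore expected in this assay, and a further limit is the most likely report.

The expected step is a step that the limit leaves unreadable from compound 3 to compound 4.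

The estimate for compound 4 is 50000 nM, with an expected range of 25000 nM to 100000 nM.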

Compound 4, half-maximal effective concentration: > 36600 nM
Compound 4: a limit, no number (the forecaster's own chance of this, stated with the estimate: 90%); the middle value does not contradict the limit.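

Compound 4 also sits at a limit and has no number of its own, so the steps to it from compound 1, compound 2 and compound 3 cannot be read: the limit of > 36600 nM in this assay, at which 4 of the 4 values shown sit.

The compounds shown leave open how these four differ in this assay, and whether any fluorine pattern on this ring gives a numerical value there.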